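The source may report more compounds than this note shows. Statements on the series, on what has been measured and on what is new or still open speak of the compounds shown alone.

Working notes on the series in a functional assay on a cell-free system (Platelet, plasma, Homo sapiens) for inhibition; on this read-out higher numbers stand for weaker inhibition and lower numbers for stronger inhibition. Compound 1 `Cc1ccc(N(CCN2CCC(OCC(=O)O)CC2)C(=O)c2ccc(F)cc2)cc1` gives 970 nM. For the measured compounds named here, compound 2 `O=C(O)COC1CCN(CCN(C(=O)c2ccc(F)cc2)c2ccc(Cl)cc2)CC1` gives 2000 nM, the higher of the two exact numbers so far. The step between them is a 2.1-fold higher number from compound 1 to compound 2 (0.31 log units; beyond the scatter). Compound 3 `O=C(O)COC1CCN(CCN(C(=O)c2ccc(-c3ccccc3)cc2)c2ccc(Cl)cc2)CC1` reads > 10000 nM, which is a limit of the assay and not a number.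

Next is compound 4 `O=C(O)COC1CCN(CCN(C(=O)c2cccc(F)c2)c2ccc(Cl)cc2)CC1`, where the change from compound 2 is 3-fluorophenyl in place of 4-fluorophenyl on a carbonyl carbon. Going by the values given here, only one measured step touches this group, an at least 5.0-fold higher number from compound 2 to compound 3 (0.69 log units; beyond the scatter), and there phenyl replaces the fluoro rather than the fluoro being moved. The other step, a 2.1-fold higher number from compound 1 to compound 2 (0.31 log units; beyond the scatter), swaps chloro for methyl elsewhere and is modest. Among the compounds with values here, no measured step moves a fluoro, so neither gives a direct size for this change. No step beyond the scatter is therefore expected in this assay. The expected step is a 1.3-fold higher number from compound 2 to compound 4 (0.10 log units; within the scatter). For compound 4 the estimated value is 2500 nM, with an expected range of 900 nM to 6500 nM.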

Compound 4, half-maximal inhibitory concentration: 340 nM
For compound 4 the middle estimate is 7.4-fold (0.87 log units) above the measured one, and the stated range ends above it.
By their numbers in this assay, from the lowest: compound 4; then compound 1; then compound 2. At a limit, above all of these: compound 3.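

In this assay, the group on the carbonyl carbon responds not only to what is attached to its ring but also to how the same atoms are joined: 3-fluorophenyl in place of 4-fluorophenyl gives a 5.9-fold lower number from compound 2 to compound 4 (0.77 log units; beyond the scatter). For the compounds shown here, until now the only change at this group was upward, an at least 5.0-fold higher number from compound 2 to compound 3 (0.69 log units; beyond the scatter), so the number at this position can move in either direction. Nothing in the data shown gives a reason for the new step.

On these data alone, it remains open whether a methoxy, nitrile or trifluoromethyl group in place of the fluoro of compound 4 would keep the lower number, or how an unsubstituted phenyl would read at this position. As far as these compounds go, it also remains open whether the same change holds with the methyl of compound 1 in place of the chloro.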